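Aminophenyl in place of methoxyphenyl on the amide of compound 2

The compounds below may be only part of what the source reports. "The series", "measured", "known", "first", "only" and "open" are said of these compounds alone.

Compound 2 `COc1cccc(/C=C/C(=O)Nc2cc(C(=O)c3cc(OC)c(OC)c(OC)c3)ccc2OC)c1` gives 3100 nM in a functional assay on HeLa cells (Homo sapiens) for cytotoxicity, read by MTT assay, with a stated time of 72 h (on this read-out lower numbers stand for stronger inhibition and higher numbers for weaker inhibition), the second highest of the three numbers: compound 1 `COc1ccc(C(=O)c2cc(OC)c(OC)c(OC)c2)cc1N` gives 60 nM and compound 3 `C#CCOc1cccc(/C=C/C(=O)Nc2cc(C(=O)c3cc(OC)c(OC)c(OC)c3)ccc2OC)c1` gives 14000 nM. Within the data shown here, the only single-change step known runs a 4.5-fold higher number from compound 2 to compound 3 (0.65 log units; beyond the scatter). Compound 4 `COc1ccc(C(=O)c2cc(OC)c(OC)c(OC)c2)cc1NC(=O)/C=C/c1ccc(N)cc1` differs from compound 2 by 4-aminophenyl in place of 3-methoxyphenyl on a double-bonded chain carbon bound to a double-bonded chain carbon. Among the measured compounds shown here, that change sits on the double-bonded chain carbon, not on the oxygen-bound chain carbon altered from compound 2 to compound 3, so no measured step bears on it directly; the nearest cue is that both measured amides, compound 2 and compound 3, stay far from compound 1. A step of about a 1.2-fold lower number from compound 2 to compound 4 (0.09 log units; within the scatter) is therefore expected, within the scatter. Compound 4 is estimated at 2500 nM, between 600 nM and 10000 nM.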

Compound 4, half-maximal inhibitory concentration: 14700 nM
Compound 4: the middle estimate sits 5.9-fold (0.77 log units) below what was measured, outside the stated range (above it).
By their numbers in this assay, from the lowest: compound 1; then compound 2; then compounds 3 and 4 (each within the scatter of the next).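

The group on the double-bonded chain carbon does affect the result: 4-aminophenyl in place of 3-methoxyphenyl gives a 4.7-fold higher number from compound 2 to compound 4 (0.68 log units; beyond the scatter) and so weakens inhibition. The 4-aminophenyl and 3-(propargyloxy)phenyl groups cannot be told apart, with a 1.1-fold higher number from compound 3 to compound 4 (0.02 log units; within the scatter) as their step. Placing the (2-(4-aminophenyl)ethenyl)carbonyl group on the nitrogen of compound 1 gives a 250-fold higher number from compound 1 to compound 4 (2.39 log units; beyond the scatter) as the largest step here.

Going by these compounds, whether the loss follows the amine or its ring position stays open, as 3-aminophenyl and 4-methoxyphenyl at this place would separate the two. No measurement at hand explains these steps.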